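Amino in place of isopropyl on a shared amide core

The source may report more compounds than this note shows. Statements on the series, on what has been measured and on what is new or still open speak of the compounds shown alone.

Measured so far:
compound 1, `CCOc1cc(C(=O)Nc2nn[nH]n2)nc(-c2ccc(N)cc2)c1`, in a functional assay on the whole organism with Rattus norvegicus as the target, at a dose of 1 mg/kg by the oral route (a higher number here means a stronger effect of the compound at the dose given, a lower number a weaker effect), compound 1 gives 52%
compound 2, `Cc1cc(C(=O)Nc2nn[nH]n2)nc(-c2ccc(C(C)C)cc2)c1`, in this assay compound 2 gives 34%

Among the two numbers, compound 2 has the lowest; its nearest neighbour, compound 1, stands higher by a gap that lies beyond the usual scatter. For the measured compounds named here, no step between the measured pair has been worked out, since the two compounds differ in more than one place, so only the two values themselves can be compared.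

The unmeasured compound 3, `Cc1cc(C(=O)Nc2nn[nH]n2)nc(-c2ccc(N)cc2)c1`, is reached from compound 2 by a single change: amino in place of isopropyl on an aromatic carbon.

Going by the values given here, because compound 1, which also carries the amino group, gives 52%, an upward step in this assay is expected here, of moderate size and likely beyond the scatter, though with no directly comparable step on record the size is uncertain. The step from compound 2 to compound 3 is estimated at a number 14 percentage points higher from compound 2 to compound 3 (beyond the scatter). Compound 3 is therefore expected to give about 48%, within a range from 30% to 65%.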

Compound 3, a percentage reported as inhibition, in the whole organism at one dose (the size of the read-out at that dose, not a potency): 75%
Estimate against measurement, compound 3: 27 percentage points below; the measured number lies above the stated range.
By their numbers in this assay, from the lowest: compound 2; then compound 1; then compound 3.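

In this assay, for the compounds shown here, amino in place of isopropyl, para to a large group on the six-membered aromatic ring, gives a number 41 percentage points higher from compound 2 to compound 3 (beyond the scatter), a large step and the first reading of this position with nothing else changed. The other substituent also counts: methyl in place of ethoxy on an aromatic carbon, with the amino group kept, gives a number 23 percentage points higher from compound 1 to compound 3 (beyond the scatter), a modest step, so the amino group alone does not set the level of the read-out. No measurement at hand accounts for either step.

As far as these compounds go, with only amino and isopropyl compared at the first position, it remains open how a hydroxyl, a methoxy or a dimethylamino group would fare there, and whether the size of the step depends on the group replaced or the group brought in. Also open, from the compounds shown here alone, are whether the amino step would be as large with ethoxy in place of methyl, and how a longer chain such as propyl would read in this assay, where each number reflects one dose and not a potency.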